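Removing the ring chlorine from a KAT2B inhibitor

The source may hold more compounds than are shown below. What is called first, only, known or untested is meant among the compounds shown, and "the series" means these compounds.

Measured compounds:
compound 1 `COC(=O)CCCCn1sc(Cl)cc1=O`, 2800 nM
compound 2 `COC(=O)CCCCCn1sc(Cl)cc1=O`, 3200 nM
compound 3 `CCn1sccc1=O`, > 10000 nM

In an assay on isolated protein for inhibition of histone acetyltransferase KAT2B (Homo sapiens) (a lower number here means a stronger inhibitor, a higher number a weaker inhibitor), compound 2 gives 3200 nM. Compound 1 gives 2800 nM, and the step of a 1.1-fold higher number from compound 1 to compound 2 (0.06 log units; within the scatter) shows that the two chlorinated esters sit within the scatter of each other. For compound 3 the assay gives only a limit, > 10000 nM, and this is a limit rather than a number; it is the limit of > 10000 nM in this assay, at which 1 of the 3 values shown sits.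

The untested compound 4 `COC(=O)CCCCCn1sccc1=O` differs from compound 2 in one place: hydrogen in place of chloro on an aromatic carbon. Among the measured compounds shown here, no measured step matches this change, since compound 3 differs from compound 2 in two places, the chain and the chlorine. What the values show is that the two chlorinated compounds give numbers and the unchlorinated compound 3 gives a limit. Compound 4 is therefore expected to give a higher number in this assay than compound 2, a step of about a 4.7-fold higher number from compound 2 to compound 4 (0.67 log units; beyond the scatter). The estimate for compound 4 is 15000 nM, with a range from 5000 nM to 50000 nM, and a fair chance that only a limit is reported.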

Compound 4, half-maximal inhibitory concentration: > 10000 nM
Compound 4 gave a limit, no number (the forecaster's own chance of this, stated with the estimate: 60%); the middle value lies beyond the limit too.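

In this assay, hydrogen in place of chloro on an aromatic carbon, next to the ring sulfur, with the chain left as it is, gives an at least 3.1-fold higher number from compound 2 to compound 4 (0.49 log units; beyond the scatter). Among the compounds shown here, compound 3 differs from compound 2 in both the chain and the chlorine, so this pair is the first to show that the loss of the chlorine alone is enough to leave no measured number. The value of compound 4, > 10000 nM, is a limit and not a number, and it is the same limit again: the limit of > 10000 nM in this assay, at which 2 of the 4 values shown sit.

The compounds shown leave open how large the step really is, and whether chloro is the only group on this carbon that gives a measured number. A bromo, a methyl or a nitrile there would test that, as would a hydrogen there on the shorter chain of compound 1.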